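Removing the carboxymethyl group from compound 3

This account rests on a few compounds, and the source may have more. Where it says the series, first, only, none or still open, it means among the compounds named here.

Measured compounds and their results:
Compound 1 `NCCn1ncc2c(NCc3ccccc3[N+](=O)[O-])cc(C(F)(F)F)cc21` gives 29% in an assay for inhibition of Tryptophan 2,3-dioxygenase (Homo sapiens), with stated times of 10 min and 60 min, tested at 100 uM; on this read-out lower numbers stand for a weaker effect and higher numbers for a stronger effect at the one concentration tested.
Compound 2 `N#Cc1cc(NCc2ccccc2[N+](=O)[O-])c2cn[nH]c2c1` gives 41% in this assay.
Compound 3 `O=C(O)CNc1cccc(CNc2cc(C(F)(F)F)cc3[nH]ncc23)c1` gives 65% in this assay.

Compound 3 stands highest of the three numbers; its nearest neighbour is compound 2, whose number is lower by more than the usual scatter, and compound 1 lies further below still.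

Compound 4 `Nc1cccc(CNc2cc(C(F)(F)F)cc3[nH]ncc23)c1` has not yet been measured. It differs from compound 3 in one place: hydrogen in place of carboxymethyl on a nitrogen on an aromatic ring. For the measured compounds named here, no pair of measured compounds shows this change, so its effect is unknown from the data. A moderate decrease in this assay is expected, beyond the scatter. Compound 4 is estimated to give 48%, in a range from 28% to 68%, which corresponds to an expected step of a number 17 percentage points lower from compound 3 to compound 4 (beyond the scatter).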

Compound 4, a percentage reported as inhibition, at one concentration (the size of the read-out at that concentration, not a potency): 89%
Beside the measured number, compound 4's estimate is 41 percentage points below it; the measured number lies above the stated range.
By their numbers in this assay, from the lowest: compound 1; then compound 2; then compound 3; then compound 4.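

Replacing carboxymethyl with hydrogen on the nitrogen on the aromatic ring brings a number 24 percentage points higher from compound 3 to compound 4 (beyond the scatter) in this assay. For the compounds shown here, this is the first comparison here that changes one place only, and it shows that the carboxymethyl group is not needed for the effect at this position and that the plain amino group does better. Nothing measured here gives a reason for this rise. Still open, going by these compounds, is whether a methyl or acetyl group on this nitrogen would stay close to compound 4, and how a longer chain ending in a carboxylic acid would compare with compound 3.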